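Compound 2 to compound 3: a dimethylamino step

The source may hold more compounds than are shown below. What is called first, only, known or untested is meant among the compounds shown, and "the series" means these compounds.

Values in a functional assay on NCI-H460 cells (Homo sapiens) for cytotoxicity, read by MTT assay, with a stated time of 48 h (a higher number here means a weaker inhibitor, a lower number a stronger inhibitor), are as follows:
compound 1 `C=C1C(=O)O[C@H]2CC3=C[C@H](C/C(C)=C/[C@@H](OC(=O)c4ccc([N+](=O)[O-])cc4)[C@H]12)OC3=O` gives > 10000 nM (a limit)
compound 2 `C=C1C(=O)O[C@H]2CC3=C[C@H](C/C(C)=C/[C@@H](OC(=O)/C=C/c4ccccc4)[C@H]12)OC3=O` gives > 10000 nM (a limit)
compound 3 `C=C1C(=O)O[C@H]2CC3=C[C@H](C/C(C)=C/[C@@H](OC(=O)/C=C/c4ccc(N(C)C)cc4)[C@H]12)OC3=O` has no value yet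

Compound 2 stands at > 10000 nM, which is a limit of the assay and not a number. Its position within the series therefore cannot be ranked. Compound 3 has dimethylamino in place of hydrogen on an aromatic carbon of the 2-phenylethenyl group, para to a large group (dimethylamino in place of hydrogen on an aromatic carbon). The same difference reads phenyl to 4-(dimethylamino)phenyl. Going by the values given here, the only measured step that bears on this change is a step that the two limits leave unreadable from compound 1 to compound 2, which also alters the group on the carbonyl carbon. Its size cannot be read, so it offers no guide to the size of the new step. All that the series shows so far is the limit of > 10000 nM in this assay, at which 2 of the 2 values shown sit. Resting on (the limit of > 10000 nM in this assay, at which 2 of the 2 values shown sit), no step beyond the scatter is expected in this assay, and the estimated step is a step that the limit leaves unreadable from compound 2 to compound 3, with no firm direction. For compound 3 the expected value is 12000 nM, with an estimated range from 4000 nM to 30000 nM, and a further limit in place of a number would not be surprising.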

Compound 3, half-maximal inhibitory concentration: 1300 nM
Compound 3: the middle estimate sits 9.2-fold (0.97 log units) above what was measured; measured number outside the range, below it.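

In this assay, going by these compounds alone, dimethylamino on an aromatic carbon of the 2-phenylethenyl group, para to a large group, is the first change with a readable effect, giving an at least 7.6-fold lower number from compound 2 to compound 3 (0.88 log units; beyond the scatter). The group on the carbonyl carbon can therefore shift the read-out in this assay, and exchanging 4-nitrophenyl for 2-(4-(dimethylamino)phenyl)ethenyl gives an at least 7.6-fold lower number from compound 1 to compound 3 (0.88 log units; beyond the scatter). Compound 3 alone gives a number, so both steps are minimum sizes and the step between compound 1 and compound 2 cannot be read: the limit of > 10000 nM in this assay, at which 2 of the 3 values shown sit.

On these data alone, it remains open whether this shift is specific to dimethylamino or would also appear with another group at the same place, such as a primary amine, methoxy or a pyrrolidine ring. Also open, as far as these compounds go, is whether the ethenyl link is needed, a question that 4-(dimethylamino)phenyl set directly on the carbonyl carbon would address through a comparison with compound 1 that differs in one place only.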